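This account rests on a few compounds, and the source may have more. Where it says the series, first, only, none or still open, it means among the compounds named here.

Compound 1 `CN(C(=O)C(C)(C)C)c1ccc2[nH]c(-c3n[nH]c4ccccc34)cc2n1` gives 22200 nM in a functional assay on SMMC-7721 cells (Homo sapiens) for antiproliferative activity, read by MTT assay, with a stated time of 72 h; a lower number here means a stronger inhibitor, a higher number a weaker inhibitor; compound 2 `CN(C(=O)c1ccccc1)c1ccc2[nH]c(-c3n[nH]c4ccccc34)cc2n1` gives 12500 nM; compound 3 `CN(C(=O)CCc1ccccc1)c1ccc2[nH]c(-c3n[nH]c4ccccc34)cc2n1` gives 20900 nM.

Compound 3 stands second highest of the three numbers, with compound 1 nearest and compound 2 furthest, both separations within the scatter. Compound 4 `CN(C(=O)c1ccc(Br)cc1)c1ccc2[nH]c(-c3n[nH]c4ccccc34)cc2n1` differs from compound 3 by 4-bromophenyl in place of phenethyl on a carbonyl carbon. The measured step that bears on this is a 1.7-fold higher number from compound 2 to compound 3 (0.22 log units; within the scatter), which stayed within the scatter; a 1.8-fold lower number from compound 1 to compound 2 (0.25 log units; within the scatter) and a 1.1-fold lower number from compound 1 to compound 3 (0.03 log units; within the scatter) were likewise within it. Undoing the phenethyl-to-phenyl change, with bromine added, is therefore expected to give no step in this assay beyond the scatter, leaning if anything toward a lower number. Compound 4 is estimated at 13000 nM, within 5000 nM to 35000 nM. This expectation corresponds to a 1.6-fold lower number from compound 3 to compound 4 (0.21 log units; within the scatter).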

Compound 4, half-maximal inhibitory concentration: 3460 nM
Beside the measured number, compound 4's estimate is 3.8-fold (0.57 log units) above it; measured number below the stated range.
By their numbers in this assay, from the lowest: compound 4; then compounds 2, 3 and 1 (each within the scatter of the next).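

In this assay, within the data shown here, bromo in place of hydrogen on an aromatic carbon gives a 3.6-fold lower number from compound 2 to compound 4 (0.56 log units; beyond the scatter), the first step beyond the scatter; exchanging tert-butyl, phenyl and phenethyl on the carbonyl carbon had produced none. The 4-bromophenyl group also stands apart from the two other groups, with a 6.0-fold lower number from compound 3 to compound 4 (0.78 log units; beyond the scatter) and a 6.4-fold lower number from compound 1 to compound 4 (0.81 log units; beyond the scatter). Nothing measured here accounts for this gain. From the compounds shown here alone, it remains open whether the gain is specific to bromine or would also appear with a 4-chlorophenyl, 4-methoxyphenyl or 4-aminophenyl group.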